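Chlorinated purine benzyl series: growth inhibition notes

The compounds below may be only part of what the source reports. "The series", "measured", "known", "first", "only" and "open" are said of these compounds alone.

Measured so far:
compound 1 `ClCc1ccc(Cn2cnc3c(Cl)ncnc32)cc1` — > 100000 nM
compound 2 `ClCc1cccc(Cn2cnc3ncnc(Cl)c32)c1` — 22900 nM
compound 3 `ClCc1ccc(Cn2cnc3c(Cl)nc(Cl)nc32)cc1` — 43700 nM

In a functional assay on SK-MEL-2 cells (Homo sapiens) for cytotoxicity, read by sulforhodamine B assay, with a stated time of 48 h (a higher number here means a weaker inhibitor of growth, a lower number a stronger inhibitor of growth), compound 1 reaches only the limit (the limit of > 100000 nM in this assay, at which 1 of the 3 values shown sits), not a number. Compound 3 carries chloro in place of hydrogen on an aromatic carbon relative to compound 1, and the step of an at least 2.2-fold lower number from compound 1 to compound 3 (0.35 log units; beyond the scatter) follows. Compound 2 shares the same atoms as compound 1, joined differently; the difference between the two cores is not broken down here. In this assay compound 2 gives 22900 nM and compound 3 gives 43700 nM, two values that lie within the scatter of each other, so no order between them is claimed.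

Compound 4 `ClCc1cccc(Cn2cnc3nc(Cl)nc(Cl)c32)c1` is not yet measured. It differs from compound 2 by chloro in place of hydrogen on an aromatic carbon, the same change as that from compound 1 to compound 3, at a place described in identical terms. The expectation for compound 4 rests on the step of an at least 2.2-fold lower number from compound 1 to compound 3 (0.35 log units; beyond the scatter) seen in compound 3; a step of comparable size, estimated as a 2.1-fold lower number from compound 2 to compound 4 (0.32 log units; beyond the scatter), is expected here. Compound 4 is therefore estimated at 11000 nM in this assay, with a likely range from 4000 nM to 30000 nM.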

Compound 4, concentration for total growth inhibition: 3710 nM
The estimate for compound 4 lay 3.0-fold (0.47 log units) above the measured number; measured number below the stated range.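

In this assay, chloro in place of hydrogen on an aromatic carbon again goes with a lower number on a second core, with a 6.2-fold lower number from compound 2 to compound 4 (0.79 log units; beyond the scatter). Set beside the earlier step, the change points the same way on both cores, but their sizes cannot be ranked: the same change on two cores in this assay, an at least 2.2-fold lower number (0.35 log units; beyond the scatter) from compound 1 to compound 3 and a 6.2-fold lower number (0.79 log units; beyond the scatter) from compound 2 to compound 4; the limit leaves it open whether they differ This shows a shared direction across these two pairs only; it does not show that the size of the step carries from one core to another, or that the direction holds on any further core.

The compounds shown leave open whether an amine or a methoxy group in that same place, between two ring nitrogen atoms, would go with a number as low as that of the chloro group. Also open, on these data alone, is whether the step survives when the chloromethyl group on the benzyl ring gives way to a hydroxymethyl group or a longer chain.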